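Replacing the 2,5-Dimethoxyphenyl Group: An Expected Inhibition

A few compounds are considered here, and "the series" means these few. Any claim that something is new, unique, unknown or untested is made for them only; others in the source may bear on it.

Compound 1, `COc1ccc(OC)c(N2C(=O)CSC2c2cccc(C(=O)NCCCCc3ccccc3)c2)c1`: 2%
Compound 2, `CCOc1ccccc1N1C(=O)C(C)SC1c1cccc(C(=O)NCCCCc2ccccc2)c1`: 53%

Both compounds were tested in a functional assay on 143B cells (Homo sapiens) for inhibition, read by CCK-8 assay, with a stated time of 72 h, tested at 1 uM; a higher number here means more inhibition at the concentration tested (going by the name of the read-out), a lower number less inhibition. Compound 1 stands lowest of the two numbers; compound 2 sits higher by a margin beyond the usual scatter, but the two differ in more than one place, so no single step can be read from them. Compound 3 `CC(F)(F)c1cccc(N2C(=O)CSC2c2cccc(C(=O)NCCCCc3ccccc3)c2)c1` is not yet measured. It differs from compound 1 in one place: a group of 10 heavy atoms (8 carbon, 2 fluorine; one six-membered aromatic ring of carbon only) in place of a group of 10 heavy atoms (8 carbon, 2 oxygen; one six-membered aromatic ring of carbon only), on an amide-type nitrogen in a ring. The shared core and the rest of compound 1 are unchanged. Going by the values given here, with no measured step of this kind, the direction is open; a modest rise is expected, since compound 1 starts near the floor and a fall of any size would stay within scatter. The estimated step of a number 13 percentage points higher from compound 1 to compound 3 (beyond the scatter) is small. Compound 3 is expected to give about 15% in this assay, with a range from 0% to 50%.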

Compound 3, a percentage reported as inhibition, at one concentration (the size of the read-out at that concentration, not a potency): 1%
For compound 3 the middle estimate is 14 percentage points above the measured one, and the stated range covers the measured number.
By their numbers in this assay, from the lowest: compounds 3 and 1 (each within the scatter of the next); then compound 2.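

In this assay, putting the new aryl group, with its two fluorine atoms and no hydrogen-bond acceptors, in place of the 2,5-dimethoxyphenyl group on the amide-type nitrogen gives a number 1 percentage points lower from compound 1 to compound 3 (within the scatter). Going by these compounds alone, this is the first single-place step at this position, and it shows that the two hydrogen-bond acceptors counted on the group that leaves can go without a change in the read-out beyond the scatter. No measurement at hand offers a reason for this result.

Compound 1 differs from compound 2 in more than one place, so the compounds shown do not tell which of those differences goes with the value of compound 2, 53%. They also leave open how an aryl group bearing an amine or a carboxylic acid would read at this position.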